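A Halogen in the Place of Methoxy on the Cinnamoyl Arm

The source may report more compounds than this note shows. Statements on the series, on what has been measured and on what is new or still open speak of the compounds shown alone.

The series shares one hydrazide core, and three members have been tested in a functional assay on cells (Cancer cell lines, Homo sapiens) for inhibition, read by MTT assay, with a stated time of 48 h; on this read-out higher numbers stand for weaker inhibition and lower numbers for stronger inhibition. Compound 1 `COc1cccc(/C=C/C(=O)NNC(=O)c2ccc3c(c2)OCCO3)c1` gives 170 nM in this assay, the lowest of the three numbers, and both other compounds lie beyond the scatter from it. Compound 2 `O=C(/C=C/c1ccccc1Cl)NNC(=O)c1ccc2c(c1)OCCO2` gives 4880 nM, and compound 3 `O=C(/C=C/c1cccc(Cl)c1)NNC(=O)c1ccc2c(c1)OCCO2` gives 3560 nM; the step of a 1.4-fold lower number from compound 2 to compound 3 (0.14 log units; within the scatter) lies within the scatter, so these two stand together.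

Compound 4 `O=C(/C=C/c1cccc(F)c1)NNC(=O)c1ccc2c(c1)OCCO2` is the next step from compound 1. The change is fluoro in place of methoxy on an aromatic carbon, so a fluoro enters on the aromatic carbon where the methoxy stood. Within the data shown here, the closest precedent is the step of a 21-fold higher number from compound 1 to compound 3 (1.32 log units; beyond the scatter), in which a chloro replaced the same methoxy and the number rose sharply; the step of a 29-fold higher number from compound 1 to compound 2 (1.46 log units; beyond the scatter) points the same way. Both show that removing the methoxy from this ring costs much, and nothing in the series suggests that fluoro would behave differently from chloro here. Compound 4 is therefore expected to show a large rise, a 15-fold higher number from compound 1 to compound 4 (1.17 log units; beyond the scatter), and its half-maximal inhibitory concentration is estimated at 2500 nM, with a likely range from 600 nM to 8000 nM.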

Compound 4, half-maximal inhibitory concentration: 4110 nM
For compound 4 the middle estimate is 1.6-fold (0.22 log units) below the measured one, within the range that was stated.
By their numbers in this assay, from the lowest: compound 1; then compounds 3, 4 and 2 (each within the scatter of the next).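

In this assay the step of a 24-fold higher number from compound 1 to compound 4 (1.38 log units; beyond the scatter) is large, so the loss that came with chloro in place of methoxy on this aromatic carbon also comes with fluoro and does not depend on chloro alone. The choice between these two halogens makes no readable difference here: the step of a 1.2-fold higher number from compound 3 to compound 4 (0.06 log units; within the scatter) lies within the scatter, and the step of a 1.2-fold lower number from compound 2 to compound 4 (0.07 log units; within the scatter) also lies within it, which places the 3-fluorophenyl of compound 4 together with the 2-chlorophenyl of compound 2 and the 3-chlorophenyl of compound 3. No measurement shown accounts for the gap between the 3-methoxyphenyl compound and these three halogen compounds.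

On these data alone, what remains open is which part of the methoxy matters, its oxygen or its carbon, a question that a hydroxy, a methyl or an ethoxy on the same aromatic carbon would address. As far as these compounds go, it is also open whether the 3-methoxyphenyl is unusual within a wider set of groups, and an amine or a carboxylic acid at this place would test that.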